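Swapping one five-membered ring for another on a urea

This account rests on a few compounds, and the source may have more. Where it says the series, first, only, none or still open, it means among the compounds named here.

Measured so far:
compound 1 `Cc1cc(C)c(NC(=O)N(Cc2ccc(-c3nnc(C)o3)cc2)C2CCCCCC2)c(C)c1`, 27 nM
compound 2 `Cc1cc(C)c(NC(=O)N(Cc2ccc(-n3ccnc3)cc2)C2CCCCCC2)c(C)c1`, 47 nM

Both compounds share a urea core and differ only in the small aromatic ring hanging from the benzyl group. In an assay on microsomes from intestine for inhibition of acyl-CoA:cholesterol acyltransferase (Oryctolagus cuniculus) (a higher number here means a weaker inhibitor, a lower number a stronger inhibitor), compound 1 gives 27 nM, and compound 2 gives 47 nM. Compound 2 has the highest of the two numbers, but its nearest neighbour is compound 1, and the step of a 1.7-fold higher number from compound 1 to compound 2 (0.24 log units; within the scatter) stays within the scatter, so the two cannot be ordered.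

Compound 3 `Cc1cc(C)c(NC(=O)N(Cc2ccc(-n3ccnn3)cc2)C2CCCCCC2)c(C)c1` carries the change (1H-1,2,3-triazol-1-yl in place of 1H-imidazol-1-yl on an aromatic carbon). Within the data shown here, the only measured step that touches this part of the molecule is a 1.7-fold higher number from compound 1 to compound 2 (0.24 log units; within the scatter), which exchanged one five-membered aromatic ring for another without a meaningful change in this assay. That single precedent suggests such ring swaps at this position are tolerated, though one step is a thin basis.

Compound 3 is therefore expected to stay close to compound 2, with a step of a 1.1-fold higher number from compound 2 to compound 3 (0.03 log units; within the scatter) that does not go beyond the scatter. The estimate for compound 3 in this assay is 50 nM, with a range from 20 nM to 125 nM.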

Compound 3, half-maximal inhibitory concentration: 42 nM
Compound 3: middle estimate off by 1.2-fold (0.08 log units), on the high side; the range from low to high includes it.
By their numbers in this assay, from the lowest: compounds 1, 3 and 2 (each within the scatter of the next).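

In this assay, trading a ring carbon for a nitrogen, which turns 1H-imidazol-1-yl into 1H-1,2,3-triazol-1-yl, gives no readable change (a 1.1-fold lower number from compound 2 to compound 3 (0.05 log units; within the scatter)), and the new ring also stays within the scatter when set directly against 5-methyl-1,3,4-oxadiazol-2-yl (a 1.6-fold higher number from compound 1 to compound 3 (0.19 log units; within the scatter)). Among these compounds, the single earlier ring swap now has company: three five-membered aromatic rings with different sets of hetero atoms cannot be ordered at this place on the six-membered aromatic ring, para to a large group, and none of the three compounds goes against that. Nothing shown here explains why these rings give such similar numbers.

All three groups are five-membered aromatic rings, so these compounds do not show whether this place would accept a different kind of group, such as an amine, a carboxylic acid or a longer alkyl chain. They also leave open whether any ring is needed here, since a plain hydrogen at this place would be the direct test, and whether a six-membered pyridine ring would fit in the same way.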